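The source may report more compounds than this note shows. Statements on the series, on what has been measured and on what is new or still open speak of the compounds shown alone.

Measured in a functional assay on HeLa cells (Homo sapiens) for antiproliferative activity, read by MTT assay; a lower number here means a stronger inhibitor, a higher number a weaker inhibitor:
Compound 1, `CCOC(=O)/C=N/c1cnc(Nc2ccc(N3CCN(C)CC3)cc2)nc1NC1CCCC1`: 19000 nM.
Compound 2, `CN1CCN(c2ccc(Nc3ncc(/N=C/c4ccccc4)c(NC4CCCC4)n3)cc2)CC1`: > 100000 nM, which is a limit of the assay and not a number.
Compound 3, `CCOC(=O)/C=N/c1cnc(Nc2ccc(N3CCN(C)CC3)cc2)nc1NC(C)C`: 11500 nM.

Compound 3 has the lowest of the two numbers; its nearest neighbour is compound 1, and a 1.7-fold lower number from compound 1 to compound 3 (0.22 log units; within the scatter), so the two cannot be told apart on these data. Compound 4, `CC(C)Nc1nc(Nc2ccc(N3CCN(C)CC3)cc2)ncc1/N=C/c1ccccc1`, is not yet measured. It differs from compound 3 in one place: phenyl in place of ethoxycarbonyl on a carbon with a double bond to nitrogen. The same change has been measured once before, between compound 1 and compound 2, where an at least 5.2-fold higher number from compound 1 to compound 2 (0.72 log units; beyond the scatter); that step ran into (the limit of > 100000 nM in this assay, at which 1 of the 3 values shown sits). The same direction, and at least a similar size, is therefore expected here, so compound 4 is estimated to show a 7.0-fold higher number from compound 3 to compound 4 (0.84 log units; beyond the scatter) in this assay. The expected value for compound 4 is 80000 nM, with a range from 40000 nM to 200000 nM, and with a fair chance that this assay again reports only the limit rather than a number.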

Compound 4, half-maximal inhibitory concentration: > 100000 nM
Compound 4: no number, only a limit; the forecaster's own chance of this, stated with the estimate: 55%; at least 1.2-fold (0.09 log units) between middle value and limit.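

In this assay, phenyl in place of ethoxycarbonyl on a carbon with a double bond to nitrogen weakens a second compound pair, now with isopropyl instead of cyclopentyl on the nitrogen, and here there is an at least 8.6-fold higher number from compound 3 to compound 4 (0.93 log units; beyond the scatter). The loss therefore does not belong to the cyclopentyl pair alone: the same change on two cores in this assay, an at least 5.2-fold higher number (0.72 log units; beyond the scatter) from compound 1 to compound 2 and an at least 8.6-fold higher number (0.93 log units; beyond the scatter) from compound 3 to compound 4; the limit leaves it open whether they differ. As far as these compounds go, compound 2 and compound 4 each give only a limit of the assay and not a number, so the step between them cannot be read, and how far phenyl weakens either compound stays open: the limit of > 100000 nM in this assay, at which 2 of the 4 values shown sit.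

With only these two groups shown at this position, it remains open whether ethoxycarbonyl itself matters or whether another group would serve as well. A carboxylic acid, an amide or a longer ester chain on that carbon could settle this.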